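The compounds below may be only part of what the source reports. "The series", "measured", "known", "first", "only" and "open" are said of these compounds alone.

In an ADME assay on microsomes from liver (Mus musculus) for metabolic stability, read by LC-MS, using NADPH, with stated times of 10 min and 30 min, tested at 1 uM (on this read-out higher numbers stand for fast clearance and lower numbers for slow clearance), compound 1 `COC(=O)C1=C(C)NC(c2nccs2)=NC1(C)c1ccc(Cl)cc1` gives 85 mL/min/kg, compound 2 `COC(=O)C1=C(CN2CC3CC2CO3)NC(c2nccs2)=NC1(C)c1ccc(F)cc1` gives 84 mL/min/kg and compound 3 `COC(=O)C1=C(CN2CCC(F)(F)CC2)NC(c2nccs2)=NC1(C)c1ccc(F)cc1` gives 88 mL/min/kg. Compound 3 thus stands within the scatter of both others. Compound 4 `COC(=O)C1=C(Cn2ccnc2)NC(c2nccs2)=NC1(C)c1ccc(F)cc1` differs from it as follows: 1H-imidazol-1-yl in place of 4,4-difluoropiperidin-1-yl on a saturated chain carbon bound to a double-bonded ring carbon. In words, 1H-imidazol-1-yl replaces 4,4-difluoropiperidin-1-yl on a saturated chain carbon bound to a double-bonded ring carbon. Among the measured compounds shown here, the only measured step at this place, a 1.0-fold higher number from compound 2 to compound 3 (0.02 log units; within the scatter), lies within the scatter, but it joins two non-aromatic groups, so it offers only limited guidance for an aromatic one. The expected step is small, a 1.2-fold lower number from compound 3 to compound 4 (0.09 log units; within the scatter), and is not expected to exceed the scatter. The estimated clearance of compound 4 is 72 mL/min/kg, with an expected range of 42 mL/min/kg to 98 mL/min/kg.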

Compound 4, clearance: 69 mL/min/kg
The estimate for compound 4 lay 1.0-fold (0.02 log units) above the measured number; the range from low to high includes it.
By their numbers in this assay, from the lowest: compounds 4, 2, 1 and 3 (each within the scatter of the next).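

In this assay, an aromatic group at this place leaves the read-out within the scatter of both non-aromatic groups, with a 1.3-fold lower number from compound 3 to compound 4 (0.11 log units; within the scatter) and a 1.2-fold lower number from compound 2 to compound 4 (0.09 log units; within the scatter). The 1H-imidazol-1-yl group and the non-aromatic groups on this saturated chain carbon therefore cannot be told apart on this read-out. No measured evidence bears on this result. Still open, from the compounds shown here alone, is whether a carboxylic acid or a longer chain on this carbon would give a number beyond the scatter. Also open, going by these compounds, is whether an amide in place of the methyl ester would do so.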